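This account rests on a few compounds, and the source may have more. Where it says the series, first, only, none or still open, it means among the compounds named here.

Measured in a functional assay on the whole organism for antagonist activity, with Mus musculus as the target; on this read-out lower numbers stand for an effect already at smaller amounts and higher numbers for an effect only at larger amounts of compound:
Compound 1 `COC(=O)N(C)CC#CCn1cncc1C`: 5.4 mg/kg
Compound 2 `COC(=O)N(C)C(C)C#CCn1ccnc1`: > 100 mg/kg, a limit of the assay
Compound 3 `COC(=O)N(C)C(C)C#CCn1cncc1C`: 6.6 mg/kg

Compound 3 stands level with compound 1 in this assay, as a 1.2-fold higher number from compound 1 to compound 3 (0.09 log units; within the scatter) shows. Compound 2 gives no number to compare, only a limit.

Compound 4 `CCOC(=O)N(C)C(C)C#CCn1cncc1C` differs from compound 3 at the carbamate-free end of the naming only in its ester group, and the change is methyl in place of hydrogen on a saturated chain carbon bound to an oxygen next to a carbonyl group: methoxycarbonyl becomes ethoxycarbonyl, with methyl in place of hydrogen on a saturated chain carbon bound to an oxygen next to a carbonyl group.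

For the measured compounds named here, no measured step touches this place, so the evidence is indirect. The nearest comparison is also a methyl in place of hydrogen on a saturated chain carbon, and it amounted to a 1.2-fold higher number from compound 1 to compound 3 (0.09 log units; within the scatter). The other methyl step was large, an at least 15-fold lower number from compound 2 to compound 3 (1.18 log units; beyond the scatter), but it lies on an aromatic carbon, so it says little about the ester while warning that a single methyl can matter. On the strength of the first of these, no change beyond the scatter is expected, only a wider uncertainty. The expected outcome is a 1.1-fold higher number from compound 3 to compound 4 (0.03 log units; within the scatter).

Compound 4 is therefore estimated at 7 mg/kg, with an expected range from 2.5 mg/kg to 25 mg/kg.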

Compound 4, dose for half-maximal effect: 17.3 mg/kg
Estimate against measurement, compound 4: 2.5-fold (0.39 log units) below; the measured number falls inside the stated range.
By their numbers in this assay, from the lowest: compounds 1 and 3 (each within the scatter of the next); then compound 4. At a limit, above all of these: compound 2.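

In this assay, the ester end of the molecule turns out to respond to a single methyl: the change from methoxycarbonyl to ethoxycarbonyl gives a 2.6-fold higher number from compound 3 to compound 4 (0.42 log units; beyond the scatter), a modest step, but one that clears the scatter. The earlier methyl on a saturated chain carbon, which gave a 1.2-fold higher number from compound 1 to compound 3 (0.09 log units; within the scatter), stayed within the scatter, so in these compounds a methyl on a saturated chain carbon does not always leave the read-out unchanged, and the place where it enters matters. Nothing in the data at hand gives a reason for this shift.

On these data alone, this place is still described by one step alone, so it remains open whether a longer chain such as propyl or butyl, a branched isopropyl or a benzyl group on the ester oxygen would carry the number further in the same direction. As far as these compounds go, it is equally open whether an amine in place of that oxygen would be tolerated, and whether ethoxycarbonyl would give a similar step on compound 1, which lacks the methyl on the chain carbon.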